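Imidazole in place of aminoimidazoline on the sulfonamide core

A few compounds are considered here, and "the series" means these few. Any claim that something is new, unique, unknown or untested is made for them only; others in the source may bear on it.

Compound 3 `CCS(=O)(=O)Nc1cccc(NC2=NCCN2)c1` gives 355 nM in an assay on isolated protein for binding affinity to Alpha-1D adrenergic receptor (Rattus norvegicus), read by radioligand binding; on this read-out higher numbers stand for weaker inhibition and lower numbers for stronger inhibition. Going by the values given here, of the three compounds measured so far it stands second highest: compound 2 `CCS(=O)(=O)Nc1cccc(C2CCNC2)c1` gives 1000 nM, and compound 1 `Oc1cccc2c1CCCC2c1c[nH]cn1`, built on a different core, gives 30.9 nM. Among the compounds with values here, the one step recorded within the shared core, a 2.8-fold lower number from compound 2 to compound 3 (0.45 log units; beyond the scatter), is the only direct guide available.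

Compound 4 `CCS(=O)(=O)Nc1cccc(-c2c[nH]cn2)c1` differs from compound 3 in one place: a group of 5 heavy atoms (3 carbon, 2 nitrogen; one five-membered aromatic ring with 2 hetero atoms) in place of a group of 6 heavy atoms (3 carbon, 3 nitrogen; one five-membered non-aromatic ring with 2 hetero atoms), on an aromatic carbon. Within the data shown here, no measured step exchanges the non-aromatic ring with 2 hetero atoms for the aromatic one, so the recorded step from compound 2 to compound 3 bears on it only indirectly, as a sign that changes at this position of the core move the number by a modest amount. Compound 1 carries the same 1H-imidazol-4-yl group on another core and shows the lowest number in this assay, which hints at, but does not establish, a favourable direction.

The step from compound 3 to compound 4 is therefore expected to be small and, if anything, toward a lower number, a 1.4-fold lower number from compound 3 to compound 4 (0.15 log units; within the scatter). Compound 4 is estimated at 250 nM, with a range from 60 nM to 1000 nM.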

Compound 4, inhibition constant: < 10000 nM
Compound 4: only a limit was reported; the forecaster's own chance of this, stated with the estimate: 5%; the middle value does not contradict the limit.
By their numbers in this assay, from the lowest: compound 1; then compound 3; then compound 2.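

Going by these compounds alone, compound 4 is recorded only as a limit, < 10000 nM, and no step from compound 2 or compound 3 to compound 4 can be read. As far as these compounds go, whether 1H-imidazol-4-yl on the shared core gives a lower or higher number than compound 3 remains open.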